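The source may report more compounds than this note shows. Statements on the series, on what has been measured and on what is new or still open speak of the compounds shown alone.

In a functional assay on UACC-257 cells (Homo sapiens) for antiproliferative activity, read by sulforhodamine B assay, with a stated time of 48 h (on this read-out higher numbers stand for weaker inhibition and lower numbers for stronger inhibition), compound 2 `C/C=C(\C)C(=O)O[C@H]1C=CC(=O)O[C@H]1COC(=O)[C@H](C)O` gives 13000 nM and compound 1 `C/C=C(\C)C(=O)O[C@H]1C=CC(=O)O[C@H]1CCC(=O)[C@H](C)O` gives 24000 nM as its value, so the two stand within the scatter of each other. Compound 3 `C/C=C(\C)C(=O)O[C@H]1C=CC(=O)O[C@H]1CNC(=O)[C@H](C)O` has ((1-hydroxyethyl)carbonyl)amino in place of ((1-hydroxyethyl)carbonyl)oxy on a saturated chain carbon bound to a saturated ring carbon, counted as ((1-hydroxyethyl)carbonyl)amino in place of ((1-hydroxyethyl)carbonyl)oxy on a saturated chain carbon bound to a saturated ring carbon in full. Going by the values given here, the one measured step at this place is a 1.8-fold lower number from compound 1 to compound 2 (0.27 log units; within the scatter) and stays within the scatter, so no step beyond the scatter is expected in this assay here. For compound 3 the estimate is 18000 nM with an expected range from 7000 nM to 45000 nM overall. This estimate means a 1.4-fold higher number from compound 2 to compound 3 (0.14 log units; within the scatter) as the expected step.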

Compound 3, half-maximal inhibitory concentration: 28000 nM
Beside the measured number, compound 3's estimate is 1.6-fold (0.19 log units) below it, and the stated range covers the measured number.
By their numbers in this assay, from the lowest: compounds 2, 1 and 3 (each within the scatter of the next, the first and the last beyond it).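

In this assay, the place on a saturated chain carbon bound to a saturated ring carbon now shows its first step beyond the scatter: ((1-hydroxyethyl)carbonyl)amino in place of ((1-hydroxyethyl)carbonyl)oxy gives a 2.2-fold higher number from compound 2 to compound 3 (0.33 log units; beyond the scatter). The same group in place of ((1-hydroxyethyl)carbonyl)methyl gives a 1.2-fold higher number from compound 1 to compound 3 (0.07 log units; within the scatter), so the change registers against only one of the two comparators. Nothing measured here accounts for this difference. The compounds shown leave open how a simple amine, a carboxylic acid or a longer chain would fare at this place.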